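Benzothiazole amide series: removing chloro from compound 2

The source may report more compounds than this note shows. Statements on the series, on what has been measured and on what is new or still open speak of the compounds shown alone.

Measured in a functional assay on A549 cells (Homo sapiens) for cytotoxicity, read by MTT assay, with a stated time of 48 h; on this read-out lower numbers stand for stronger inhibition and higher numbers for weaker inhibition:
- compound 1 `COc1ccc(-c2cc(C(=O)Nc3nc4ccc(Cl)cc4s3)nc3cc(-c4ccccc4)nn23)cc1`: 3090 nM
- compound 2 `COc1ccc(-c2cc(C(=O)Nc3nc4ccc(Cl)cc4s3)nc3cc(-c4ccccc4)nn23)cc1OC`: 6160 nM
- compound 3 `COc1cc(-c2cc(C(=O)Nc3nc4ccc(Cl)cc4s3)nc3cc(-c4ccccc4)nn23)cc(OC)c1OC`: 18200 nM

Compound 2 stands second highest of the three numbers. The step of a 2.0-fold higher number from compound 1 to compound 2 (0.30 log units; within the scatter) lies within the scatter, whereas a 3.0-fold higher number from compound 2 to compound 3 (0.47 log units; beyond the scatter) and a 5.9-fold higher number from compound 1 to compound 3 (0.77 log units; beyond the scatter) lie beyond it; only the trimethoxy compound 3 is clearly separated.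

Compound 4 `COc1ccc(-c2cc(C(=O)Nc3nc4ccccc4s3)nc3cc(-c4ccccc4)nn23)cc1OC` differs from compound 2 by hydrogen in place of chloro on an aromatic carbon. Within the data shown here, none of the three measured steps touches this part of the molecule; all of them vary the methoxy pattern on the other aryl ring, so no measured step bears directly on the change. In this assay no step beyond the scatter is therefore expected. Compound 4 is estimated at 7000 nM (range 3000 nM to 18000 nM), corresponding to an expected step of a 1.1-fold higher number from compound 2 to compound 4 (0.06 log units; within the scatter).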

Compound 4, half-maximal inhibitory concentration: 5490 nM
Estimate against measurement, compound 4: 1.3-fold (0.11 log units) above; low and high end bracket the measured number.
By their numbers in this assay, from the lowest: compounds 1, 4 and 2 (each within the scatter of the next); then compound 3.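

Until now every compound carried the 6-chloro-1,3-benzothiazol-2-yl group, and only the methoxy pattern on the other aryl ring varied. In this assay, hydrogen in place of chloro gives a 1.1-fold lower number from compound 2 to compound 4 (0.05 log units; within the scatter) and so the chloro is not required for the activity of compound 2 at this level. Nothing available gives a reason for this result.

Open, on these data alone, is whether an amine or a carboxylic acid at this position would also leave the value in place. Also open, as far as these compounds go, is whether removing chloro from compound 1 or compound 3 would give a similar result.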